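The compounds below may be only part of what the source reports. "The series", "measured", "known", "first", "only" and "open" are said of these compounds alone.

Compound 1 `COc1cc(O)c(C)c2c1CC[C@H](c1ccc(O)cc1)O2`: 59100 nM
Compound 2 `COc1ccc(C(=O)CCc2c(OC)cc(O)cc2OC)cc1`: 68100 nM

Among the compounds with values here, in a functional assay on cells (Mus musculus) for cytotoxicity, read by MTT assay, with a stated time of 72 h (on this read-out higher numbers stand for weaker inhibition and lower numbers for stronger inhibition), compound 2 gives 68100 nM, and this number lies within the usual scatter of the one for compound 1, at 59100 nM. The two compounds therefore cannot be told apart on this read-out.

Compound 3 `COc1cc(O)cc(OC)c1CCC(=O)c1ccc(O)cc1` has not yet been measured in this assay. It differs from compound 2 by a single change: hydrogen in place of methyl on an oxygen on an aromatic ring, with hydrogen in place of methyl on an oxygen on an aromatic ring, that is, methoxy to hydroxy. Within the data shown here, no measured pair shows this change, so the data offer no direct guide to its size. Only a small shift is expected, towards a lower number if there is any, and possibly none beyond the scatter. The expected change is a 1.2-fold lower number from compound 2 to compound 3 (0.09 log units; within the scatter). For compound 3 the estimated value is 55000 nM, with an expected range from 22000 nM to 120000 nM.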

Compound 3, half-maximal inhibitory concentration: 40200 nM
Beside the measured number, compound 3's estimate is 1.4-fold (0.14 log units) above it, and the stated range covers the measured number.
By their numbers in this assay, from the lowest: compounds 3, 1 and 2 (each within the scatter of the next).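

In this assay, the first measured case of methoxy going to hydroxy gives a 1.7-fold lower number from compound 2 to compound 3 (0.23 log units; within the scatter), so on this read-out the change does not separate the two compounds. At this oxygen on an aromatic ring, hydrogen can therefore stand in place of methyl without a step beyond the scatter, something compounds 1 and 2 alone could not show. No measurement of any other property bears on this result, so the data offer no explanation for the size of the step.

The compounds shown leave open whether a larger replacement at this oxygen, such as a longer alkyl chain or a chain ending in an amine or a carboxylic acid, would give a step beyond the scatter. They also leave open whether the same methoxy to hydroxy change at the remaining methoxy group of compound 3 would behave in the same way.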